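This account rests on a few compounds, and the source may have more. Where it says the series, first, only, none or still open, it means among the compounds named here.

Working notes on the series. In a functional assay on WHCO1 cells (Homo sapiens) for antiproliferative activity, read by MTT assay, with a stated time of 48 h (a lower number here means a stronger inhibitor, a higher number a weaker inhibitor), compound 1 (`C=CCSS/C=C/C[S+]([O-])CCC`) gives 37000 nM, compound 2 (`CCC[S+]([O-])C/C=C\SSC`) gives 26000 nM and compound 3 (`C=CCSS/C=C\C[S+]([O-])CCCO`) gives 38000 nM. Compound 3 therefore stands level with the other two, as its number lies within the scatter of both.

The next compound to be read is compound 4 (`C=CCSS/C=C/C[S+]([O-])CCCO`). Its difference from compound 3 is purely one of stereochemistry: the two compounds have the same atoms and bonds; at least one stereo element is drawn with a configuration in one of them and without one in the other: 1 of 2 stereo elements differ; a double bond is drawn Z in compound 3 and E in compound 4. For the measured compounds named here, no measured pair isolates this change, so the data offer no direct reading of it. Going by the values given here, the only indirect evidence is that compound 1, drawn E at its double bond, gives 37000 nM, while compound 3, drawn Z, gives 38000 nM, and these two values lie within the scatter of each other.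

No change beyond the scatter is expected, in either direction. The estimated step of a 1.1-fold lower number from compound 3 to compound 4 (0.04 log units; within the scatter) is expected to remain within the scatter. For compound 4 the expected value is 35000 nM, with an estimated range of 20000 nM to 60000 nM.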

Compound 4, half-maximal inhibitory concentration: 27000 nM
Compound 4: the middle estimate sits 1.3-fold (0.11 log units) above what was measured; the range from low to high includes it.
By their numbers in this assay, from the lowest: compounds 2, 4, 1 and 3 (each within the scatter of the next).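

For the compounds shown here, this pair gives the first direct reading of the double bond geometry: going from Z to E in this assay is a 1.4-fold lower number from compound 3 to compound 4 (0.15 log units; within the scatter), so this change alone does not move the number beyond the scatter. The hydroxy in place of hydrogen on a saturated chain carbon, three bonds along the chain from a sulfur, can now also be read directly, as a 1.4-fold lower number from compound 1 to compound 4 (0.14 log units; within the scatter), and it too stays within the scatter. The stereochemical reading carries one qualification: the fact that one of compounds 3 and 4 is drawn with a defined configuration and the other without, at the place where they differ

On these data alone, whether an amine, a carboxylic acid or a longer chain in place of the hydroxy would give a step beyond the scatter remains open. Each change is read in one pair only, so its size with the methyl disulfide of compound 2 is also unknown.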